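Swapping an ether chain for a methyl-oxazole on a shared core

A few compounds are considered here, and "the series" means these few. Any claim that something is new, unique, unknown or untested is made for them only; others in the source may bear on it.

Compound 1, `CCCCNc1nc(N)nc2ccn(Cc3nccs3)c12`, in an ADME assay on HEK293 cells (Homo sapiens) for cytotoxicity, read by ATP content, with a stated time of 6 h (on this read-out lower numbers stand for higher toxicity in this test and higher numbers for lower toxicity in this test), gives > 24000 nM, a limit of the assay rather than a number.
Compound 2, `CCCCNc1nc(N)nc2ccn(Cc3ncccc3OC)c12`, in this assay gives > 24000 nM, again a limit rather than a number.
Compound 3, `CCOCCNc1nc(N)nc2ccn(Cc3ccccn3)c12`, in this assay gives > 24000 nM, once more a limit rather than a number.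

Compound 3 therefore has no measured number of its own; it sits at the same limit as the two other compounds, as the limit of > 24000 nM in this assay, at which 3 of the 3 values shown sit, shows. Among the compounds with values here, the only step between measured compounds is a step that the two limits leave unreadable from compound 1 to compound 2, and its size cannot be read because both ends are limits. So nothing measured here tells how large a change on the shared core can move this read-out.

The new compound 4, `Cc1cc(CNc2nc(N)nc3ccn(Cc4ccccn4)c23)on1`, differs from compound 3 in one place: 3-methyl-1,2-oxazol-5-yl in place of ethoxymethyl on a saturated chain carbon bound to a nitrogen on an aromatic ring. This change does not resemble the one measured step, so it offers no direct guide, and the three limits only show that compounds of this core have so far shown no toxicity within the tested range.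

For compound 4 the expected step that the limit leaves unreadable from compound 3 to compound 4 is therefore none that would be readable, and compound 4 is estimated at 30000 nM, within 15000 nM to 60000 nM, most likely reported again as a limit.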

Compound 4, half-maximal cytotoxic concentration: > 24000 nM
Compound 4 gave a limit, no number (the forecaster's own chance of this, stated with the estimate: 85%); the middle value is on the limit's open side.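

Compound 3 and compound 4 are both reported only as limits, not numbers, so swapping ethoxymethyl for 3-methyl-1,2-oxazol-5-yl gives a step of no readable size in this assay. The compounds shown leave open whether any change on the shared core can move this read-out at all, as all of them sit at one value: the limit of > 24000 nM in this assay, at which 4 of the 4 values shown sit.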